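A Methyl Added to the Benzyl Ester of Compound 3

The source may hold more compounds than are shown below. What is called first, only, known or untested is meant among the compounds shown, and "the series" means these compounds.

Compound 3 `COc1ccc(-c2csc(N)c2C(=O)OCc2ccccc2)cc1OC` gives 100% in an assay on isolated protein for inhibition of protein kinase C zeta type (Homo sapiens), with stated times of 1 h and 2.5 min, tested at 30 uM (on this read-out lower numbers stand for less inhibition and higher numbers for more inhibition at the one concentration tested (going by the name of the read-out)), the highest of the three measured numbers. Compound 1 `COCCOC(=O)c1c(-c2ccc(OC)c(OC)c2)csc1N` gives 57%, and compound 2 `COCC(C)OC(=O)c1c(-c2ccc(OC)c(OC)c2)csc1N` gives 49%. Among the measured compounds shown here, the steps of a number 43 percentage points higher from compound 1 to compound 3 (beyond the scatter) and a number 51 percentage points higher from compound 2 to compound 3 (beyond the scatter) are both large, but neither alters the aromatic ring of the ester, so no measured step bears directly on the present change. Compound 4 `COc1ccc(-c2csc(N)c2C(=O)OCc2cccc(C)c2)cc1OC` differs from compound 3 by methyl in place of hydrogen on an aromatic carbon. The only added methyl among the measured steps, a number 8 percentage points lower from compound 1 to compound 2 (within the scatter), lies within the scatter, and compound 3 already sits at the top of the read-out. Compound 4 is therefore expected to give about 93%, between 75% and 100%. The expected step is a number 7 percentage points lower from compound 3 to compound 4 (within the scatter), within the scatter.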

Compound 4, a percentage reported as inhibition, at one concentration (the size of the read-out at that concentration, not a potency): 67%
Compound 4: the middle estimate sits 26 percentage points above what was measured, outside the stated range (below it).
By their numbers in this assay, from the lowest: compounds 2, 1 and 4 (each within the scatter of the next, the first and the last beyond it); then compound 3.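

In this assay the ring of the benzyl ester proves sensitive to one added methyl on an aromatic carbon: the change gives a number 33 percentage points lower from compound 3 to compound 4 (beyond the scatter) and is large, whereas the added methyl on the saturated chain gave only a number 8 percentage points lower from compound 1 to compound 2 (within the scatter) and stayed within the scatter. The new ester still shows a number 18 percentage points higher from compound 2 to compound 4 (beyond the scatter) but, with a number 10 percentage points higher from compound 1 to compound 4 (within the scatter) as the other comparison, it keeps no clear margin over both earlier esters. No evidence available here accounts for this loss. Open, from the compounds shown here alone, is whether chlorine, a hydroxyl group or an amine on this same aromatic carbon would behave like methyl, and whether methyl on other ring carbons costs as much.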